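The source may hold more compounds than are shown below. What is called first, only, known or untested is meant among the compounds shown, and "the series" means these compounds.

Measured so far:
- compound 1, `Cc1cccc2sc(NC(=O)CCN3CCN(CCN(C)C)CC3)nc12`: in an assay on membranes from liver for displacement of a labelled ligand from Sigma intracellular receptor 2 (Rattus norvegicus), read by scintillation counting, with a stated time of 120 min (a higher number here means a weaker inhibitor, a lower number a stronger inhibitor), compound 1 gives > 1000 nM, which is a limit of the assay and not a number.
- compound 2, `Cc1cccc2sc(NC(=O)CCN3CCN(C4CCCCC4)CC3)nc12`: in this assay compound 2 gives 233 nM.

Compound 1 stands only at a limit in this assay: the limit of > 1000 nM in this assay, at which 1 of the 2 values shown sits. For the measured compounds named here, the single measured step, an at least 4.2-fold lower number from compound 1 to compound 2 (0.63 log units; beyond the scatter), shows that putting cyclohexyl in place of 2-(dimethylamino)ethyl on the ring amine nitrogen lowers the number by at least a modest margin.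

Compound 3, `Cc1cccc2sc(NC(=O)CCN3CCN(c4ncccn4)CC3)nc12`, is not yet measured. It differs from compound 1 by pyrimidin-2-yl in place of 2-(dimethylamino)ethyl on an amine nitrogen in a ring. Going by the values given here, only the step to compound 2 bears on it, and that step concerns a different entering group, so the expectation is loose: the direction is expected to follow compound 2, the size is uncertain. Compound 3 is estimated at 400 nM, with an expected range from 100 nM to 3000 nM. The step this expectation means is an at least 2.5-fold lower number from compound 1 to compound 3 (0.39 log units; beyond the scatter).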

Compound 3, inhibition constant: > 1000 nM
Compound 3: only a limit was reported (the forecaster's own chance of this, stated with the estimate: 25%); middle value at least 2.5-fold (0.39 log units) from the limit.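

Pyrimidin-2-yl in place of cyclohexyl on the ring amine nitrogen gives an at least 4.2-fold higher number from compound 2 to compound 3 (0.63 log units; beyond the scatter) in this assay. For the compounds shown here, a ring on this nitrogen therefore does not by itself keep the number low, since the lower number so far goes with cyclohexyl and does not carry over to the aromatic pyrimidin-2-yl. The change from 2-(dimethylamino)ethyl to pyrimidin-2-yl cannot be read, because compound 1 and compound 3 both stand at a limit of the assay and not at a number: the limit of > 1000 nM in this assay, at which 2 of the 3 values shown sit.

Still open, from the compounds shown here alone, is whether the lower number belongs to cyclohexyl alone or extends to other carbon groups such as cyclopentyl or a straight hexyl chain. Also open, going by these compounds, is whether phenyl or benzyl on the same nitrogen sides with cyclohexyl or with pyrimidin-2-yl.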